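Hydroxy to methoxy: the step to compound 3

The compounds below may be only part of what the source reports. "The series", "measured", "known", "first", "only" and "open" are said of these compounds alone.

Of the compounds shown here, two have so far been read in a physicochemical assay for solubility, read by HPLC; a lower number here means a less soluble compound, a higher number a more soluble compound. In this assay compound 1 `Cc1ccc([C@H](C(=O)N2CCCC2)N2C(=O)[C@@H](C3Cc4ccccc4C3)NC(=O)[C@H]2CC(C)C)cn1` gives 241 ug/mL. In this assay compound 2 `CC(C)C[C@@H]1C(=O)N[C@H](C2Cc3ccccc3C2)C(=O)N1[C@@H](C(=O)N(C)C)c1ccc(O)nc1` reads > 240 ug/mL, which is a limit of the assay and not a number. Where compound 2 truly stands is therefore open, and only one side of its place is known.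

Compound 3 `COc1ccc([C@H](C(=O)N(C)C)N2C(=O)[C@@H](C3Cc4ccccc4C3)NC(=O)[C@H]2CC(C)C)cn1` has not yet been measured. It differs from compound 2 in a single place: methyl in place of hydrogen on an oxygen on an aromatic ring. This is methyl in place of hydrogen on an oxygen on an aromatic ring, so that 6-hydroxypyridin-3-yl becomes 6-methoxypyridin-3-yl.

Going by the values given here, no pair of measured compounds differs in one place only, so the data offer no direct guide to the size of this step. A moderate downward step in this assay is nevertheless expected, although a change no larger than the scatter would not surprise. The estimated step is an at least 1.7-fold lower number from compound 2 to compound 3 (0.23 log units; that floor lies within the scatter). For compound 3 the estimated solubility is 140 ug/mL, with an expected range from 50 ug/mL to 240 ug/mL.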

Compound 3, solubility: 216 ug/mL
For compound 3 the middle estimate is 1.5-fold (0.19 log units) below the measured one; the measured number falls inside the stated range.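

Once the hydroxy group becomes methoxy on this pyridine, this assay yields a real number rather than a limit: compound 3 gives 216 ug/mL and so stays measurable with a methyl on this oxygen. Compound 2 reads > 240 ug/mL, which is a limit of the assay and not a number. The change can be stated as an at least 1.1-fold lower number from compound 2 to compound 3 (0.04 log units; that floor lies within the scatter) and no more closely, so the data show no step beyond the scatter and cannot fix its true size, because one end of the pair is only a limit: the limit of > 240 ug/mL in this assay, at which 1 of the 3 values shown sits.

The compounds shown leave open how far compound 2 truly stands from compound 3 in this assay, and a reading of compound 2 that is a number would be needed to settle it. They also leave open what a longer chain on this oxygen, such as ethyl, or an amine in place of the hydroxy group on the 6-hydroxypyridin-3-yl ring would read in this assay, since methyl is the only group on this oxygen that the compounds shown carry.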